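The source may hold more compounds than are shown below. What is called first, only, known or untested is meant among the compounds shown, and "the series" means these compounds.

Series notes. Three analogues on a shared core carry numbers in a functional assay (Pituitary gland cell) with Rattus norvegicus as the target; a lower number here means that less compound is needed, a higher number that more compound is needed for the effect. Compound 1 `CC(C)[C@H](O)CNC(C)(C)CC(=O)N[C@@H]1CCc2ccccc2N(Cc2ccc(-c3ccccc3-c3nn[nH]n3)cc2)C1=O` gives 1000 nM. Compound 2 `CC(C)(CC(=O)N[C@@H]1CCc2ccccc2N(Cc2ccc(-c3ccccc3-c3nn[nH]n3)cc2)C1=O)NC[C@H](O)CO` gives 10 nM. Compound 3 `C[C@@H](O)CNC(C)(C)C(=O)N[C@@H]1CCc2ccccc2N(Cc2ccc(-c3ccccc3-c3nn[nH]n3)cc2)C1=O` gives 300 nM, which places it second highest of the three: a 3.3-fold lower number from compound 1 to compound 3 (0.52 log units; beyond the scatter), while a 30-fold higher number from compound 2 to compound 3 (1.48 log units; beyond the scatter). The remaining measured step, a 100-fold lower number from compound 1 to compound 2 (2.00 log units; beyond the scatter), likewise turns on an exchange of the hydroxylated chain attached through the amine nitrogen.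

Next is compound 4 `C[C@H](O)CNC(C)(C)C(=O)N[C@@H]1CCc2ccccc2N(Cc2ccc(-c3ccccc3-c3nn[nH]n3)cc2)C1=O`. Relative to compound 3, (the two compounds have the same atoms and bonds and differ only in configuration as drawn: 1 of 2 stereo elements differ; a stereocentre at a saturated chain carbon is drawn R in compound 3 and S in compound 4). None of the three measured steps concerns a change of configuration alone; each exchanges one hydroxylated chain for another, and those exchanges moved the number by amounts from modest to large. Going by the values given here, an inversion at a single centre with all atoms and bonds kept has no precedent in this set, so neither direction nor size can be read from the series, and the default expectation is a step of no change at the digits printed from compound 3 to compound 4 (within the scatter) in this assay, carried with wide uncertainty on either side. Compound 4 is therefore expected at 300 nM in this assay, within 80 nM to 1200 nM.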

Compound 4, concentration for half-maximal effect: 700 nM
Compound 4: middle estimate off by 2.3-fold (0.37 log units), on the low side, within the range that was stated.
By their numbers in this assay, from the lowest: compound 2; then compound 3; then compounds 4 and 1 (each within the scatter of the next).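

Working notes on the result. In this assay, inversion at a saturated chain carbon with all atoms and bonds kept gives a 2.3-fold higher number from compound 3 to compound 4 (0.37 log units; beyond the scatter), so this position responds to configuration alone, and the step can be assigned to that single stereocentre: the fact that compounds 3 and 4 differ only in the configuration as drawn. The exchange against compound 2 remains large with the centre drawn S, at a 70-fold higher number from compound 2 to compound 4 (1.85 log units; beyond the scatter), so inversion does not bring this chain close to the 2,3-dihydroxypropyl chain. The picture against compound 1 does shift: a 1.4-fold lower number from compound 1 to compound 4 (0.15 log units; within the scatter) lies within the scatter, whereas the same exchange with the centre drawn R lay beyond it, so whether the shorter chain separates from compound 1 depends on the configuration drawn.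

Open is whether the same direction of change would hold on the chains of compound 1 and compound 2, as the compounds shown pair both configurations only on the 2-hydroxypropyl chain. Also open, from the compounds shown here alone, is how this position would respond to a methoxy group or a carboxylic acid in place of the hydroxyl.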